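Cytotoxicity notes on a shared-core amide series

The source may report more compounds than this note shows. Statements on the series, on what has been measured and on what is new or still open speak of the compounds shown alone.

Compound 1 `CC(Sc1nnc(-c2ccncc2)s1)C(=O)Nc1ccccc1Cl`, compound 2 `CC(Sc1nnc(-c2ccncc2)s1)C(=O)NCc1ccccc1Cl` and compound 3 `O=C(CCSc1nnc(-c2ccncc2)s1)NCc1ccccc1Cl` have all been run in an ADME assay on BHK-21 cells (Mesocricetus auratus) for cytotoxicity, with a stated time of 3 days; a lower number here means that less compound is tolerated, a higher number that more compound is tolerated. In this assay compound 1 reaches only a limit, > 50000 nM. In this assay compound 2 also reaches only a limit, > 50000 nM. In this assay compound 3 likewise reaches only a limit, > 50000 nM. Compound 1 differs from compound 2 by 2-chlorophenyl in place of 2-chlorobenzyl on an amide-type nitrogen; the step that the two limits leave unreadable from compound 2 to compound 1 cannot be sized, because of the limit of > 50000 nM in this assay, at which 3 of the 3 values shown sit. The cores of compound 2 and compound 3 differ, and that difference is not broken down here.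

Compound 4 `O=C(CCSc1nnc(-c2ccncc2)s1)Nc1ccccc1Cl` remains to be measured in this assay. It differs from compound 3 by 2-chlorophenyl in place of 2-chlorobenzyl on an amide-type nitrogen, the same change already seen within the measured pair. The step from compound 3 to compound 4 is expected to be a step that the limit leaves unreadable from compound 3 to compound 4, resting on the step that the two limits leave unreadable from compound 2 to compound 1 and on (the limit of > 50000 nM in this assay, at which 3 of the 3 values shown sit). Compound 4 is therefore estimated at 60000 nM in this assay, with a range from 30000 nM to 150000 nM.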

Compound 4, half-maximal cytotoxic concentration: > 50000 nM
Compound 4 gave a limit, no number; the forecaster's own chance of this, stated with the estimate: 85%; the middle value is on the limit's open side.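

No new step can be read: compound 4 joins compound 3 at a limit of this assay, and the size of the change between them stays unreadable because of where the values sit: the limit of > 50000 nM in this assay, at which 4 of the 4 values shown sit.

The compounds shown leave open whether 2-chlorophenyl in place of 2-chlorobenzyl on an amide-type nitrogen changes the read-out in this assay at all.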